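A Whole-Ring Swap on a Shared Core

The source may hold more compounds than are shown below. What is called first, only, known or untested is meant among the compounds shown, and "the series" means these compounds.

Of the compounds shown here, three sharing one core have been measured in a functional assay on MCF7 cells (Homo sapiens) for antiproliferative activity, read by MTT assay, with stated times of 24 h and 72 h; on this read-out lower numbers stand for stronger inhibition and higher numbers for weaker inhibition. Compound 1 `COc1ccc([C@@H]2[C@H](Oc3ccccc3)C(=O)N2c2cc(OC)c(OC)c(OC)c2)cc1` gives 35000 nM in this assay. Compound 2 `COc1cc(N2C(=O)[C@@H](Oc3ccccc3)[C@H]2c2ccc(Br)cc2)cc(OC)c1OC` gives 48000 nM in this assay, and compound 3 `COc1cc(N2C(=O)[C@@H](Oc3ccccc3)[C@H]2c2ccc(N=[N+]=[N-])cc2)cc(OC)c1OC` gives 23000 nM in this assay. Among the three numbers, that of compound 3 is the lowest: compound 1 sits within the scatter of it, while compound 2 is furthest away, as shown by a 2.1-fold lower number from compound 2 to compound 3 (0.32 log units; beyond the scatter), a step beyond the scatter but modest. The other two steps, a 1.4-fold higher number from compound 1 to compound 2 (0.14 log units; within the scatter) and a 1.5-fold lower number from compound 1 to compound 3 (0.18 log units; within the scatter), stay within the scatter.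

Compound 4 `COc1ccc([C@@H]2[C@H](Oc3ccccc3)C(=O)N2c2cc(OC)c(OC)c(OC)c2)c(N)c1O` has not yet been measured. It differs from compound 3 as follows: a group of 10 heavy atoms (7 carbon, 1 nitrogen, 2 oxygen; one six-membered aromatic ring of carbon only) in place of a group of 9 heavy atoms (6 carbon, 3 nitrogen; one six-membered aromatic ring of carbon only), on a saturated ring carbon. Every measured step exchanges a single group on an aromatic carbon, and none of them moved the number by much; the change to compound 4 replaces the whole ring and its group, so those steps bear on it only loosely. The expectation is therefore no step beyond the scatter, a 1.3-fold higher number from compound 3 to compound 4 (0.12 log units; within the scatter), though with wide uncertainty. Compound 4 is thus expected to give 30000 nM in this assay, within a range from 10000 nM to 90000 nM.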

Compound 4, half-maximal inhibitory concentration: 19000 nM
The estimate for compound 4 lay 1.6-fold (0.20 log units) above the measured number; the range from low to high includes it.
By their numbers in this assay, from the lowest: compounds 4, 3, 1 and 2 (each within the scatter of the next, the first and the last beyond it).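

At the saturated ring carbon next to the ring nitrogen, the whole aromatic ring could be exchanged for one with 2 hydrogen-bond donors and 3 hydrogen-bond acceptors, where 4-azidophenyl has 0 donors and 1 hydrogen-bond acceptor, and in this assay the outcome is a 1.2-fold lower number from compound 3 to compound 4 (0.08 log units; within the scatter) and so no real shift. The same holds against the ring of compound 1, with a 1.8-fold lower number from compound 1 to compound 4 (0.27 log units; within the scatter) as the step, so the earlier exchanges of a single group and this exchange of an entire ring both leave the number in one narrow band. Only the ring of compound 2 stands apart, with a 2.5-fold lower number from compound 2 to compound 4 (0.40 log units; beyond the scatter) as a step beyond the scatter yet modest, much like a 2.1-fold lower number from compound 2 to compound 3 (0.32 log units; beyond the scatter) seen before, so the entering ring adds no new behaviour.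

Nothing else at hand bears on this result. Still open, as far as these compounds go, is whether a ring carrying a carboxylic acid or a longer alkyl chain at this position would leave that band, and whether the phenoxy group, the same in all four compounds, could give way to an amine without moving the number.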